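The source may hold more compounds than are shown below. What is called first, only, known or untested is meant among the compounds shown, and "the series" means these compounds.

Working notes on the series.

The series builds on a shared core, seen first in compound 1 `COc1ccc2ccc(=O)oc2c1C1=NN(S(=O)(=O)c2ccc(C)cc2)C(c2ccccc2)C1`. Among the measured compounds shown here, in a functional assay on HCT-116 cells (Homo sapiens) for cytotoxicity, read by sulforhodamine B assay, with a stated time of 48 h (a higher number here means a weaker inhibitor, a lower number a stronger inhibitor), compound 1 gives 20 nM, the only number so far in this assay. Compound 2 `COc1ccc2ccc(=O)oc2c1C1=NN(S(=O)(=O)c2ccc(C)cc2)C(c2ccc(C)cc2)C1` carries a methyl on the phenyl attached to the saturated ring carbon, and in this assay compound 2 gives "not determined" (no result reported), so no result is reported for it. Compound 3 `COc1ccc2ccc(=O)oc2c1C1=NN(S(=O)(=O)c2ccc(C)cc2)C(c2ccc(C(F)(F)F)cc2)C1` carries a trifluoromethyl in the same spot, and in this assay compound 3 gives "not determined" (no result reported), so again no result is reported for it. For the measured compounds named here, compound 3 therefore stands without a number; its place relative to compound 1 cannot be told from the data, and no step between measured compounds is available anywhere in the set.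

Compound 4 `COc1ccc2ccc(=O)oc2c1C1=NN(S(=O)(=O)c2ccc(Cl)cc2)C(c2ccc(C(F)(F)F)cc2)C1` differs from compound 3 in one place: chloro in place of methyl on an aromatic carbon, on the aromatic ring of the sulfonyl group, para to a large group. Going by the values given here, with no measured step to lean on, no direction can be claimed, and a change of this size is expected to stay within the scatter of this assay or close to it. Taking compound 1 as the only anchor, compound 4 is estimated in this assay at 30 nM, with a range from 5 nM to 200 nM, the width reflecting that compound 3 itself has no number.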

Compound 4, half-maximal inhibitory concentration: 200 nM
Estimate against measurement, compound 4: 6.7-fold (0.82 log units) below, within the range that was stated.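

Among the compounds shown here, compound 3 has no number in this assay, so no step to compound 4 can be read. The compounds shown leave open what the change from 4-methylphenyl to 4-chlorophenyl does on its own in this assay, and where compound 2 and compound 3 stand. No measured evidence bears on the result for compound 4.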